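The source may report more compounds than this note shows. Statements on the series, on what has been measured and on what is new or still open speak of the compounds shown alone.

Three compounds share one core and have been examined in a functional assay on MCF7 cells (Homo sapiens) for cytotoxicity, read by MTT assay, with a stated time of 24 h; a higher number here means a weaker inhibitor, a lower number a stronger inhibitor. Compound 1 `Cc1ccc(NS(=O)(=O)c2ccc3ccccc3c2)cc1Nc1nccc(-c2cccnc2)n1` gives 12000 nM in this assay. Compound 2 `COc1ccc(S(=O)(=O)Nc2ccc(C)c(Nc3nccc(-c4cc(OC)c(OC)c(OC)c4)n3)c2)cc1` gives 12300 nM in this assay. Compound 3 `COc1ccc(S(=O)(=O)Nc2ccc(C)c(Nc3nccc(-c4cc(OC)c(OC)c(OC)c4)n3)c2)cc1OC` gives 11600 nM in this assay, and its number sits alongside those of compound 1 and compound 2, all three within the scatter of one another. Among the measured compounds shown here, the only single-point step so far, a 1.1-fold lower number from compound 2 to compound 3 (0.03 log units; within the scatter), therefore moved nothing that can be trusted.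

Compound 4 `COc1cc(-c2ccnc(Nc3cc(NS(=O)(=O)c4ccc5ccccc5c4)ccc3C)n2)cc(OC)c1OC` is not yet measured. It differs from compound 3 by naphthalen-2-yl in place of 3,4-dimethoxyphenyl on a sulfonyl sulfur. For the measured compounds named here, no measured pair isolates this exchange on the sulfonyl sulfur: compound 1 carries the naphthalen-2-yl group but also a different group on the core, so its value and that of compound 3 show only that both land near the same number. With nothing beyond the scatter anywhere in this set, the expected step of a 1.0-fold higher number from compound 3 to compound 4 (0.01 log units; within the scatter) is no change beyond the scatter. Compound 4 is therefore estimated at 12000 nM in this assay, with a range from 6000 nM to 24000 nM.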

Compound 4, half-maximal inhibitory concentration: 11600 nM
Beside the measured number, compound 4's estimate is 1.0-fold (0.01 log units) above it; the measured number falls inside the stated range.
By their numbers in this assay, from the lowest: compounds 3, 4, 1 and 2 (each within the scatter of the next).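

With the rest of the molecule held fixed, the exchange on the sulfonyl sulfur can now be read directly in this assay: naphthalen-2-yl in place of 3,4-dimethoxyphenyl gives (no change at the digits printed from compound 3 to compound 4 (within the scatter)), and in place of 4-methoxyphenyl it gives (a 1.1-fold lower number from compound 2 to compound 4 (0.03 log units; within the scatter)), so swapping one or two methoxy-bearing rings for the two-ring group shifts nothing beyond the scatter. Among the compounds shown here, the other place is also isolated for the first time, with 3,4,5-trimethoxyphenyl in place of pyridin-3-yl on an aromatic carbon giving (a 1.0-fold lower number from compound 1 to compound 4 (0.01 log units; within the scatter)). No independent evidence bears on this flat result.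

The compounds shown carry only aromatic rings on the sulfonyl sulfur, so a short alkyl chain or a ring bearing a carboxylic acid there remains open. From the compounds shown here alone, whether an amine on that aromatic carbon would move the number beyond the scatter in this assay also remains open.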